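This account rests on a few compounds, and the source may have more. Where it says the series, first, only, none or still open, it means among the compounds named here.

Of the compounds shown here, three have so far been tested in a functional assay on HeLa cells (Homo sapiens) for antiproliferative activity, read by MTT assay, with a stated time of 48 h; on this read-out lower numbers stand for stronger inhibition and higher numbers for weaker inhibition. Compound 1 `CNCC(=O)Nc1cc(OC)ccc1C(=O)c1ccc(OC)c2c1OC(C)(C)C=C2` gives 870 nM, compound 2 `COc1ccc(C(=O)c2cc(OC)c(OC)c(OC)c2)c(NC(=O)CN(C)C)c1` gives 470 nM, and compound 3 `C=C(c1ccc(OC)cc1NC(=O)CN)c1ccc(OC)c2c1OC(C)(C)C=C2` gives 120 nM. Compound 3 thus has the lowest number of the three, and its gaps to both others lie beyond the usual scatter of repeated measurements.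

Compound 4 `C=C(c1ccc(OC)cc1NC(=O)CNCC)c1ccc(OC)c2c1OC(C)(C)C=C2` matches compound 3 except at one place, with ethyl in place of hydrogen on an amine nitrogen. Among the measured compounds shown here, no measured pair isolates this kind of change, so its size cannot be read directly from the data. There is only a weak hint: compound 1 at 870 nM and compound 2 at 470 nM also carry groups on their amine nitrogen and have higher numbers, but they differ from compound 3 elsewhere too. A modest loss of strength is therefore expected, and the estimated step is a 1.7-fold higher number from compound 3 to compound 4 (0.22 log units; within the scatter). That step may not clear the scatter. For compound 4 the expected value is 200 nM, with an estimated range of 80 nM to 500 nM.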

Compound 4, half-maximal inhibitory concentration: 1090 nM
The estimate for compound 4 lay 5.5-fold (0.74 log units) below the measured number, and the stated range ends below it.
By their numbers in this assay, from the lowest: compound 3; then compounds 2, 1 and 4 (each within the scatter of the next, the first and the last beyond it).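

In this assay, among the compounds shown here, compounds 3 and 4 form the first pair that isolates a change on this amine nitrogen, and ethyl in place of hydrogen gives a 9.1-fold higher number from compound 3 to compound 4 (0.96 log units; beyond the scatter). This step lies beyond the scatter, so on this core the nitrogen does not accept an added ethyl without a clear loss of inhibition. The data shown offer no measurement that accounts for the size of this step.

As far as these compounds go, it remains open whether a propyl chain, a cyclopropyl group or a hydroxyethyl chain on the same nitrogen would match the hydrogen of compound 3 or the ethyl of compound 4. From the compounds shown here alone, it is also open whether ethyl in place of hydrogen would produce a step of similar size on a different core.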